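A methoxybenzyl swap after a limit reading

This account rests on a few compounds, and the source may have more. Where it says the series, first, only, none or still open, it means among the compounds named here.

- compound 1 `OC[C@H]1O[C@@H](n2cnc3c(NCc4ccccc4F)ncnc32)[C@H](O)[C@@H]1O`: 33200 nM
- compound 2 `Cc1ccc(CNc2ncnc3c2ncn3[C@@H]2O[C@H](CO)[C@@H](O)[C@H]2O)cc1`: > 166000 nM

Both compounds were tested in a functional assay on K562 cells (Homo sapiens) for antiproliferative activity, with a stated time of 72 h; a higher number here means a weaker inhibitor, a lower number a stronger inhibitor. There, compound 2 gives > 166000 nM, which is a limit of the assay and not a number.

Compound 3 `COc1cccc(CNc2ncnc3c2ncn3[C@@H]2O[C@H](CO)[C@@H](O)[C@H]2O)c1` has 3-methoxyphenyl in place of 4-methylphenyl on a saturated chain carbon bound to a nitrogen on an aromatic ring. Among the compounds with values here, the one measured step at this place is an at least 5.0-fold higher number from compound 1 to compound 2 (0.69 log units; beyond the scatter), beyond the scatter. Compound 1, at 33200 nM, suggests that a measurable value is possible here, so a modest move towards a lower number is expected. The expected change is an at least 1.6-fold lower number from compound 2 to compound 3 (0.22 log units; that floor lies within the scatter). For compound 3 the estimate is 100000 nM, with an expected range of 30000 nM to 250000 nM.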

Compound 3, half-maximal inhibitory concentration: > 166000 nM
Compound 3: no number, only a limit (the forecaster's own chance of this, stated with the estimate: 50%); middle value at least 1.6-fold (0.22 log units) from the limit.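

Compound 3 also gives a limit of the assay and not a number, so in this assay a second group at this place, 3-methoxyphenyl, joins 4-methylphenyl at that reading: the limit of > 166000 nM in this assay, at which 2 of the 3 values shown sit. Set against the 2-fluorophenyl group of compound 1, the change to 3-methoxyphenyl gives an at least 5.0-fold higher number from compound 1 to compound 3 (0.69 log units; beyond the scatter). The step between the two limit compounds cannot be read.

From the compounds shown here alone, whether compound 2 and compound 3 differ at all therefore stays open. Also open, going by these compounds, is what an unsubstituted phenyl, a pyridyl group or a longer chain would give at this place.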